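The source may hold more compounds than are shown below. What is called first, only, known or untested is meant among the compounds shown, and "the series" means these compounds.

Compound 1 `CCc1nc2ccccc2n1CCCCOc1ccc(Cl)cc1Cl` gives 23 uM
Compound 2 `CCc1nc2ccccc2n1CCCCOc1ccc(C)c(Cl)c1` gives 14 uM

Both compounds were tested in an ADME assay on Vero cells (Chlorocebus sabaeus) for cytotoxicity, read by luminescence, with a stated time of 2 days (on this read-out higher numbers stand for lower toxicity in this test and lower numbers for higher toxicity in this test), and their numbers lie within the usual scatter of each other, so compound 2 cannot be ranked apart from compound 1. Compound 3 (`CCc1nc2ccccc2n1CCCCOc1ccc(Cl)cc1C`) is still unmeasured. It keeps the shared core and chain, but carries 4-chloro-2-methylphenyl in place of 3-chloro-4-methylphenyl on the oxygen (4-chloro-2-methylphenyl in place of 3-chloro-4-methylphenyl on an oxygen on a saturated carbon). The two groups are made of the same atoms, joined differently. Among the compounds with values here, only one measured step bears on this change (a 1.6-fold lower number from compound 1 to compound 2 (0.22 log units; within the scatter)), a swap of the group at the same place, and it stayed within the scatter. One step is thin evidence, but it gives no reason to expect a larger move here. The expected step (a 1.3-fold higher number from compound 2 to compound 3 (0.11 log units; within the scatter)) is therefore no move beyond the scatter. For compound 3 the estimated value is 18 uM with an expected range from 8 uM to 40 uM when measured.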

Compound 3, half-maximal toxic concentration: 20 uM
Beside the measured number, compound 3's estimate is 1.1-fold (0.05 log units) below it, and the stated range covers the measured number.
By their numbers in this assay, from the lowest: compounds 2, 3 and 1 (each within the scatter of the next).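

In this assay, moving the same atoms around the ring on the oxygen, with 4-chloro-2-methylphenyl in place of 3-chloro-4-methylphenyl, gives a 1.4-fold higher number from compound 2 to compound 3 (0.15 log units; within the scatter) and stays within the scatter. Methyl in place of chloro on an aromatic carbon, a single swap that the earlier pair did not isolate, gives a 1.2-fold lower number from compound 1 to compound 3 (0.06 log units; within the scatter) and also stays within the scatter. Across these three compounds, then, neither the arrangement of these groups nor this exchange separates the numbers, and no supporting measurement offers an explanation for the small differences.

As far as these compounds go, whether an amine or a carboxylic acid on this aromatic ring would move the number beyond the scatter remains open. So does the outcome of a longer chain in place of the one shared here.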